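The source may hold more compounds than are shown below. What is called first, only, known or untested is meant among the compounds shown, and "the series" means these compounds.

Values in a functional assay on T47D cells (Homo sapiens) for cytotoxicity, read by CCK-8 assay and cell counting, with a stated time of 2 days (a higher number here means a weaker inhibitor, a lower number a stronger inhibitor), for the measured compounds:

Compound 1, `Oc1ccc(-c2cc(-c3ccccc3)nc(-c3ccccc3Cl)c2)cc1`: 5460 nM
Compound 2, `Oc1ccc(-c2cc(-c3cccc(Cl)c3)nc(-c3ccco3)c2)cc1`: 5220 nM
Compound 3, `Oc1cccc(-c2cc(-c3ccccc3)nc(-c3cccc(Cl)c3)c2)c1`: 3700 nM

Compound 3 gives the lowest of the three numbers in this assay, but the gap to compound 2 and the gap to compound 1 both lie within the scatter, so no order among the three can be read from these values. Compound 1 and compound 2 each carry a 4-hydroxyphenyl group, while compound 3 carries a 3-hydroxyphenyl group; the numbers do not separate these.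

Compound 4, `Oc1ccc(-c2cc(-c3ccccc3)nc(-c3cccc(Cl)c3)c2)cc1`, is the next candidate in this assay. It differs from compound 3 in one place: 4-hydroxyphenyl in place of 3-hydroxyphenyl on an aromatic carbon The two have the same atoms, joined differently. Among the measured compounds shown here, no measured pair in the set shows this change on its own, so no direct step size is available. With all three measured values sitting within the scatter of one another, the step of a 1.2-fold higher number from compound 3 to compound 4 (0.09 log units; within the scatter) is expected to be small, with no direction beyond the scatter. Compound 4 is expected to give 4500 nM, with a range from 2000 nM to 10000 nM.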

Compound 4, half-maximal inhibitory concentration: 4790 nM
For compound 4 the middle estimate is 1.1-fold (0.03 log units) below the measured one; the measured number falls inside the stated range.
By their numbers in this assay, from the lowest: compounds 3, 4, 2 and 1 (each within the scatter of the next).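

In this assay, at the position opposite the ring nitrogen, 4-hydroxyphenyl in place of 3-hydroxyphenyl gives a 1.3-fold higher number from compound 3 to compound 4 (0.11 log units; within the scatter), so this direct pair shows no readable effect of exchanging these two hydroxyphenyl isomers. The other two single changes also stay within the scatter: phenyl in place of furan-2-yl gives a 1.1-fold lower number from compound 2 to compound 4 (0.04 log units; within the scatter), and 3-chlorophenyl in place of 2-chlorophenyl gives a 1.1-fold lower number from compound 1 to compound 4 (0.06 log units; within the scatter). No supporting measurement bears on these steps.

Still open, as far as these compounds go, is whether any change at this position can produce a step beyond the scatter, for example an amine or a carboxylic acid in place of the hydroxyl group. Also open, from the compounds shown here alone, is whether the flat picture across these four compounds holds on the shared core when the phenyl or chlorophenyl groups give way to a longer chain.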